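Chloro to ethoxy on the anilino-type series

The source may report more compounds than this note shows. Statements on the series, on what has been measured and on what is new or still open speak of the compounds shown alone.

Values in a functional assay on HL-60 cells (Homo sapiens) for antiproliferative activity, read by MTT assay, with a stated time of 72 h; a lower number here means a stronger inhibitor, a higher number a weaker inhibitor:
compound 1 `COc1cc(C(=O)c2sc3ccccc3c2-c2ccc(F)cc2)cc(OC)c1OC`: 3200 nM
compound 2 `COc1ccc(-c2c(C(=O)c3cc(OC)c(OC)c(OC)c3)sc3ccccc23)c(OC)c1`: 4600 nM
compound 3 `COc1cc(C(=O)c2sc3ccccc3c2Nc2ccc(Cl)cc2)cc(OC)c1OC`: 5400 nM

All three compounds lie close together. Compound 3 stands at 5400 nM, and its separation from the other two is small: a 1.7-fold higher number from compound 1 to compound 3 (0.23 log units; within the scatter), and a 1.2-fold higher number from compound 2 to compound 3 (0.07 log units; within the scatter). The remaining pair shows the same picture, with a 1.4-fold higher number from compound 1 to compound 2 (0.16 log units; within the scatter).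

The next compound to be tested is compound 4 `CCOc1ccc(Nc2c(C(=O)c3cc(OC)c(OC)c(OC)c3)sc3ccccc23)cc1`. It keeps the core and the amino link of compound 3 and carries ethoxy in place of chloro on an aromatic carbon, para to a large group (ethoxy in place of chloro on an aromatic carbon).

Among the compounds with values here, no measured step makes this exchange itself, so the data give no direct reading of it. The closest evidence is the three steps above, each of which replaces a whole group on the shared core and none of which leaves the scatter. The present change is smaller than those, so a large shift has no support in these three compounds. The step expected in this assay is a 1.2-fold lower number from compound 3 to compound 4 (0.08 log units; within the scatter), which is an estimate of no real change beyond the scatter and carries no firm direction. For compound 4 the estimated value is 4500 nM, with an expected range from 1800 nM to 11000 nM.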

Compound 4, half-maximal inhibitory concentration: 500 nM
For compound 4 the middle estimate is 9.0-fold (0.95 log units) above the measured one; measured number outside the range, below it.
By their numbers in this assay, from the lowest: compound 4; then compounds 1, 2 and 3 (each within the scatter of the next).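

In this assay, within the data shown here, the group on the aromatic carbon para to a large group proves to matter: ethoxy in place of chloro gives an 11-fold lower number from compound 3 to compound 4 (1.03 log units; beyond the scatter), the first step beyond the scatter, whereas the earlier exchanges of whole groups all stayed within it. The (4-ethoxyphenyl)amino group also separates from the aryl groups held directly on the shared core, with 2,4-dimethoxyphenyl replaced in a 9.2-fold lower number from compound 2 to compound 4 (0.96 log units; beyond the scatter) and 4-fluorophenyl replaced in a 6.4-fold lower number from compound 1 to compound 4 (0.81 log units; beyond the scatter), so compound 4 stands apart from all three earlier compounds. The amino link alone does not set this level, since compound 3 carries it too and remains within the scatter of compound 1 and compound 2.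

Nothing in the available data explains the size of this step. Going by these compounds, whether the drop belongs to ethoxy alone or extends to methoxy, a propoxy chain or a dimethylamino group on this carbon stays open, as does whether ethoxy on a phenyl held directly on the core, without the amino link, gives the same drop.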